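One More Methyl on the Chain of Compound 2

The compounds below may be only part of what the source reports. "The series", "measured", "known", "first", "only" and "open" are said of these compounds alone.

In a functional assay on K562 cells (Homo sapiens) for antiproliferative activity, read by CellTiter-Glo, with a stated time of 72 h (on this read-out lower numbers stand for an effect already at smaller amounts and higher numbers for an effect only at larger amounts of compound), compound 1 `CCCCCNc1ncnc2c1ncn2[C@@H]1O[C@H](COS(N)(=O)=O)[C@@H](O)[C@H]1O` gives 181 nM and compound 2 `CCCCCCNc1ncnc2c1ncn2[C@@H]1O[C@H](COS(N)(=O)=O)[C@@H](O)[C@H]1O` gives 160 nM. For the measured compounds named here, compound 2 therefore stands level with compound 1, the only other compound measured so far. Compound 3 `CCCCCCCNc1ncnc2c1ncn2[C@@H]1O[C@H](COS(N)(=O)=O)[C@@H](O)[C@H]1O` is reached from compound 2 by methyl in place of hydrogen on a saturated chain carbon, six bonds along the chain from a nitrogen on an aromatic ring, which extends the same chain. Going by the values given here, one measured step bears on this change: a 1.1-fold lower number from compound 1 to compound 2 (0.05 log units; within the scatter). That step is the same kind of change, a methyl in place of hydrogen, made five bonds along the chain from a nitrogen on an aromatic ring, and it stays within the scatter. The data hold no longer chain, so this single step is a thin guide. No shift beyond the scatter is expected in this assay. The expected change is a 1.1-fold lower number from compound 2 to compound 3 (0.03 log units; within the scatter). For compound 3 the estimated value is 150 nM, with an expected range of 75 nM to 340 nM.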

Compound 3, half-maximal effective concentration: 132 nM
Beside the measured number, compound 3's estimate is 1.1-fold (0.06 log units) above it, within the range that was stated.
By their numbers in this assay, from the lowest: compounds 3, 2 and 1 (each within the scatter of the next).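

In this assay the methyl placed six bonds along the chain from a nitrogen on an aromatic ring gives a 1.2-fold lower number from compound 2 to compound 3 (0.08 log units; within the scatter), so a second extension at this end of the chain also stays inside the scatter. The wider comparison, ethyl in place of hydrogen five bonds along the chain, gives a 1.4-fold lower number from compound 1 to compound 3 (0.14 log units; within the scatter) and is also within the scatter, so even the two extensions taken together do not separate these compounds on this read-out. Nothing at hand accounts for this level response to chain extension.

From the compounds shown here alone, whether a still longer chain would move the number beyond the scatter remains open. So does the effect of a polar end group, such as an amine or a carboxylic acid, at the tip of the chain.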